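This account rests on a few compounds, and the source may have more. Where it says the series, first, only, none or still open, it means among the compounds named here.

Working notes on the series. Compound 3 `CCCc1nc(-c2ccccc2)c(CNCCN2CCN(c3cccc(Cl)c3)CC2)o1` gives 51.2% in an assay on HEK293 cells for inhibition of Voltage-dependent T-type calcium channel subunit alpha-1G (Homo sapiens), read by fluorescence, tested at 10 uM; a lower number here means less inhibition, a higher number more inhibition at the concentration tested (going by the name of the read-out). Compound 1 `CCCc1nc(-c2ccccc2)c(CNCCN2CCN(c3ccccc3Cl)CC2)o1` gives 60.1%, and compound 2 `CCCc1nc(-c2ccccc2)c(CNCCN2CCN(c3ccc(Cl)cc3)CC2)o1` gives 55.8%; the steps of a number 4.3 percentage points lower from compound 1 to compound 2 (within the scatter), a number 8.9 percentage points lower from compound 1 to compound 3 (within the scatter) and a number 4.6 percentage points lower from compound 2 to compound 3 (within the scatter) are all within the scatter, so the three numbers cannot be told apart. Compound 4 `CCCc1nc(-c2ccccc2)c(CNCCN2CCN(c3ccc(OC)cc3)CC2)o1` carries 4-methoxyphenyl in place of 3-chlorophenyl on an amine nitrogen in a ring. Going by the values given here, no measured step introduces a methoxy group, so the only bearing steps are the chlorine position changes on the same ring nitrogen, none of which moved the read-out beyond the scatter. For compound 4 the expected step is therefore a number 1.2 percentage points lower from compound 3 to compound 4 (within the scatter), nothing beyond the scatter in either direction. Compound 4 is estimated at 50%, with a range from 30% to 70%.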

Compound 4, a percentage reported as inhibition, at one concentration (the size of the read-out at that concentration, not a potency): 51.5%
Compound 4: the middle estimate sits 1.5 percentage points below what was measured, within the range that was stated.
By their numbers in this assay, from the lowest: compounds 3, 4, 2 and 1 (each within the scatter of the next).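

Methoxy in place of chloro on an aromatic carbon (a number 4.3 percentage points lower from compound 2 to compound 4 (within the scatter)) leaves the number in this assay level, so a change of group at this position, like a change of chlorine position, gives no step beyond the scatter. The same holds for the other two steps to 4-methoxyphenyl (a number 0.3 percentage points higher from compound 3 to compound 4 (within the scatter) and a number 8.6 percentage points lower from compound 1 to compound 4 (within the scatter)). No evidence bears on why these numbers cannot be told apart. On these data alone, whether an amine or a carboxylic acid on this phenyl ring would give a step beyond the scatter remains open. So does the outcome with 2-methoxyphenyl or 3-methoxyphenyl.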